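The source may report more compounds than this note shows. Statements on the series, on what has been measured and on what is new or still open speak of the compounds shown alone.

Compound 1 `COc1ccc(C2N=C(SCc3ccc(Cl)cc3)NC(C)=C2C(=O)Nc2ccc(F)cc2)cc1OC`: 20.1%
Compound 2 `COc1ccc(C2N=C(SCc3ccc(F)cc3)NC(C)=C2C(=O)Nc2ccc(F)cc2)cc1OC`: 22.2%
Compound 3 `CC1=C(C(=O)Nc2ccc(Br)cc2)C(c2ccc(Cl)cc2Cl)N=C(SCc2ccc(Cl)cc2)N1`: 23.2%

Of the compounds shown here, three have been tested in a functional assay on the whole organism (artery, strain albino) with Rattus norvegicus as the target, with a stated time of 180 min, at a dose of 10 mg/kg by the oral route; on this read-out higher numbers stand for more inhibition at the one dose given (going by the name of the read-out) and lower numbers for less inhibition. Compound 1 and compound 2 share one core and differ by fluoro in place of chloro on an aromatic carbon; the step of a number 2.1 percentage points higher from compound 1 to compound 2 (within the scatter) is small. Compound 3 carries a different core, and the difference between the two cores is not broken down here; its value and those of compound 1 and compound 2 all lie within the usual scatter of one another, so no order among the three can be read from these numbers.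

Compound 4 `CC1=C(C(=O)Nc2ccc(Br)cc2)C(c2ccc(Cl)cc2Cl)N=C(SCc2ccc(F)cc2)N1` is the next to be measured in this assay. It differs from compound 3 by fluoro in place of chloro on an aromatic carbon, the same change that turns compound 1 into compound 2, at the same place. Because that change gave a number 2.1 percentage points higher from compound 1 to compound 2 (within the scatter), the step from compound 3 to compound 4 is expected to be similarly small, a number 1.8 percentage points higher from compound 3 to compound 4 (within the scatter). On this basis compound 4 is estimated to give about 25%, most likely somewhere between 14% and 36%.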

Compound 4, a percentage reported as inhibition, in the whole organism at one dose (the size of the read-out at that dose, not a potency): 28.4%
Estimate against measurement, compound 4: 3.4 percentage points below, within the range that was stated.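

Fluoro in place of chloro in the (4-chlorobenzyl)sulfanyl group gave a number 5.2 percentage points higher from compound 3 to compound 4 (within the scatter) in this assay. Set beside the same change on the core of compound 1, the two steps give no sign that the core alters the outcome: the same change on two cores in this assay, a number 2.1 percentage points higher (within the scatter) from compound 1 to compound 2 and a number 5.2 percentage points higher (within the scatter) from compound 3 to compound 4, 3.1 percentage points apart, within the scatter of two such steps This shows only that no difference between the two cores can be seen; since each step lies within the scatter, it does not show that the change alters inhibition on either core, nor that the step would keep a fixed size on a third core.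

The compounds shown leave open what a group other than a halogen would do at this place on the aromatic ring, such as a methoxy group, a nitrile, an amine or a carboxylic acid, and whether any of these would give a step beyond the scatter. They also leave open whether replacing the whole benzyl group with a longer chain would do so.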